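Methoxy for trifluoromethyl on a pyrrolidinyl-bearing core

The source may report more compounds than this note shows. Statements on the series, on what has been measured and on what is new or still open speak of the compounds shown alone.

Of the compounds shown here, three with a shared core have been tested in a functional assay on MKN-45 cells (Homo sapiens) for cytotoxicity, read by MTT assay, with a stated time of 72 h; a lower number here means a stronger inhibitor, a higher number a weaker inhibitor. Compound 1 `COc1cc2c(Oc3ccc(NC(=O)c4cc(-c5ccc(C(F)(F)F)cc5)ccn4)cc3F)ccnc2cc1OCCCN1CCCCC1` gives 870 nM, compound 2 `COc1ccc(-c2ccnc(C(=O)Nc3ccc(Oc4ccnc5cc(OCCCN6CCCCC6)c(OC)cc45)c(F)c3)c2)cc1` gives 570 nM, and compound 3 `COc1cc2c(Oc3ccc(NC(=O)c4cc(-c5ccc(C(F)(F)F)cc5)ccn4)cc3F)ccnc2cc1OCCCN1CCCC1` gives 260 nM. Compound 3 differs from compound 1 by pyrrolidin-1-yl in place of piperidin-1-yl on a saturated chain carbon, three bonds along the chain from an oxygen on an aromatic ring, a change that made a 3.3-fold lower number from compound 1 to compound 3 (0.52 log units; beyond the scatter). Compound 2 differs from compound 1 by methoxy in place of trifluoromethyl on an aromatic carbon, a change that made a 1.5-fold lower number from compound 1 to compound 2 (0.18 log units; within the scatter).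

Compound 4 `COc1ccc(-c2ccnc(C(=O)Nc3ccc(Oc4ccnc5cc(OCCCN6CCCC6)c(OC)cc45)c(F)c3)c2)cc1` has not been measured. It differs from compound 3 by methoxy in place of trifluoromethyl on an aromatic carbon, the same change as that from compound 1 to compound 2. Because that earlier step was a 1.5-fold lower number from compound 1 to compound 2 (0.18 log units; within the scatter), compound 4 is expected to show a step of similar size, a 1.4-fold lower number from compound 3 to compound 4 (0.16 log units; within the scatter). In this assay compound 4 is therefore estimated at 180 nM, within a range of 80 nM to 400 nM.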

Compound 4, half-maximal inhibitory concentration: 150 nM
For compound 4 the middle estimate is 1.2-fold (0.08 log units) above the measured one; low and high end bracket the measured number.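

In this assay, methoxy in place of trifluoromethyl gives a 1.7-fold lower number from compound 3 to compound 4 (0.24 log units; within the scatter), and this step matches the one seen on the piperidin-1-yl core: the same change on two cores in this assay, a 1.5-fold lower number (0.18 log units; within the scatter) from compound 1 to compound 2 and a 1.7-fold lower number (0.24 log units; within the scatter) from compound 3 to compound 4, 1.1-fold (0.06 log units) apart, within the scatter of two such steps. Pyrrolidin-1-yl in place of piperidin-1-yl gives a 3.8-fold lower number from compound 2 to compound 4 (0.58 log units; beyond the scatter), and this step likewise carries over between cores: the same change on two cores in this assay, a 3.3-fold lower number (0.52 log units; beyond the scatter) from compound 1 to compound 3 and a 3.8-fold lower number (0.58 log units; beyond the scatter) from compound 2 to compound 4, 1.1-fold (0.06 log units) apart, within the scatter of two such steps. The two changes therefore combine consistently across these four compounds, but both methoxy steps lie within the scatter, so they establish no gain from methoxy itself, and two cores in one assay do not make a rule for the wider series.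

The compounds shown leave open how a chlorine or an amine would behave in place of methoxy on that aromatic carbon. They also leave open how a morpholine or a longer chain would compare with the pyrrolidin-1-yl chain.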